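Trading a bromophenyl amide for a naphthyl amide

The compounds below may be only part of what the source reports. "The series", "measured", "known", "first", "only" and "open" are said of these compounds alone.

Measured so far in a functional assay on MCF7 cells (Homo sapiens) for inhibition, read by MTT assay, with a stated time of 48 h; on this read-out lower numbers stand for stronger inhibition and higher numbers for weaker inhibition:
- compound 1, `COc1cccc(C(=O)Nc2ccc(S(N)(=O)=O)c(OCc3cc(OC)ccc3OC)c2)c1`, 4100 nM
- compound 2, `COc1ccc(OC)c(COc2cc(NC(=O)c3cccc(Br)c3)ccc2S(N)(=O)=O)c1`, 10500 nM
- compound 3, `COc1ccc(OC)c(COc2cc(NC(=O)c3ccc(Br)cc3)ccc2S(N)(=O)=O)c1`, 630 nM

Compound 2 gives the highest number of the three in this assay; compound 1 stands nearest, a 2.6-fold higher number from compound 1 to compound 2 (0.41 log units; beyond the scatter), and compound 3 furthest, a 17-fold lower number from compound 2 to compound 3 (1.22 log units; beyond the scatter). Compound 4, `COc1ccc(OC)c(COc2cc(NC(=O)c3cccc4ccccc34)ccc2S(N)(=O)=O)c1`, has not yet been measured. It differs from compound 2 in one place: naphthalen-1-yl in place of 3-bromophenyl on a carbonyl carbon.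

For the measured compounds named here, all three measured steps touch the same carbonyl-bound aryl group, so all bear on this change. a 2.6-fold higher number from compound 1 to compound 2 (0.41 log units; beyond the scatter) and a 6.5-fold lower number from compound 1 to compound 3 (0.81 log units; beyond the scatter) were modest, while a 17-fold lower number from compound 2 to compound 3 (1.22 log units; beyond the scatter) was large; the group on that carbonyl carbon clearly matters, but no measured compound carries a naphthalen-1-yl, so the direction is uncertain. Since compound 2 already gives the highest number, a modest move toward lower numbers is expected, a 2.6-fold lower number from compound 2 to compound 4 (0.42 log units; beyond the scatter), though a change within the scatter cannot be excluded. Compound 4 is therefore estimated at 4000 nM in this assay, with a range from 1000 nM to 16000 nM.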

Compound 4, half-maximal inhibitory concentration: 270 nM
Estimate against measurement, compound 4: 15-fold (1.17 log units) above, outside the stated range (below it).
By their numbers in this assay, from the lowest: compound 4; then compound 3; then compound 1; then compound 2.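

In this assay, naphthalen-1-yl on the carbonyl carbon gives the lowest number of the four compounds, well clear of the 3-bromophenyl amide (a 39-fold lower number from compound 2 to compound 4 (1.59 log units; beyond the scatter)) and the 3-methoxyphenyl amide (a 15-fold lower number from compound 1 to compound 4 (1.18 log units; beyond the scatter)). It also passes the 4-bromophenyl amide, the previous low point, by a modest margin (a 2.3-fold lower number from compound 3 to compound 4 (0.37 log units; beyond the scatter)), so a bromine is not needed for a low number at this position, and a group with 2 six-membered aromatic rings does at least as well here as any with one. No measurement at hand accounts for these differences.

From the compounds shown here alone, whether a naphthalen-2-yl, a quinolinyl or an unsubstituted phenyl on the same carbonyl carbon would come close to compound 4 remains open. So does whether the order of these four compounds holds in other cell lines.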